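The source may hold more compounds than are shown below. What is called first, only, known or untested is meant among the compounds shown, and "the series" means these compounds.

Values here come from a functional assay on cells (Cancer cell lines, Homo sapiens) for cytotoxicity, read by sulforhodamine B assay, with a stated time of 48 h; a lower number here means a stronger inhibitor of growth, a higher number a weaker inhibitor of growth.

Measured compounds:
compound 1 `COc1ccc(C2CC(c3ccccc3)=NN2C2=NC(=O)/C(=C3\C(=O)Nc4ccccc43)S2)cc1`: 6040 nM
compound 2 `COc1ccc(C2CC(c3ccccc3)=NN2C2=NC(=O)/C(=C3\C(=O)Nc4ccc(Br)cc43)S2)cc1`: 510 nM
compound 3 `COc1ccc(C2=NN(C3=NC(=O)/C(=C4\C(=O)Nc5ccccc54)S3)C(c3ccc(Cl)cc3)C2)cc1`: 100000 nM

Compound 1 and compound 2 share a core and differ by bromo in place of hydrogen on an aromatic carbon. This change gave a 12-fold lower number from compound 1 to compound 2 (1.07 log units; beyond the scatter). Compound 3 carries a different core; how it differs from the core of compound 1 is not broken down here. Its number in this assay is the highest of the three, and its distance to compound 1 and to compound 2 lies beyond the scatter in each case.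

Compound 4 `COc1ccc(C2=NN(C3=NC(=O)/C(=C4\C(=O)Nc5ccc(Br)cc54)S3)C(c3ccc(Cl)cc3)C2)cc1` is not yet measured. It stands to compound 3 as compound 2 stands to compound 1: the change is bromo in place of hydrogen on an aromatic carbon, the same change as before, at a place described in the same words. Within the data shown here, with only one measured instance of this change, on another core, the expected step for compound 4 is a 10-fold lower number from compound 3 to compound 4 (1.00 log units; beyond the scatter) in this assay, resting on the size of a 12-fold lower number from compound 1 to compound 2 (1.07 log units; beyond the scatter) from compound 1 to compound 2. Compound 4 is accordingly estimated at 10000 nM, with a range from 2500 nM to 50000 nM.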

Compound 4, concentration for total growth inhibition: 340 nM
Compound 4: the middle estimate sits 29-fold (1.47 log units) above what was measured; the whole stated range lies above it.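

In this assay, bromo in place of hydrogen on an aromatic carbon again gives a lower number, now with a 290-fold lower number from compound 3 to compound 4 (2.47 log units; beyond the scatter), so the direction of the change is the same on both cores shown. The size of the step does not carry over from one core to the other: the same change on two cores in this assay, a 12-fold lower number (1.07 log units; beyond the scatter) from compound 1 to compound 2 and a 290-fold lower number (2.47 log units; beyond the scatter) from compound 3 to compound 4, 25-fold (1.40 log units) apart, beyond the scatter of two such steps These two pairs show only that the direction held twice and that a step size taken from one core was a poor guide on the other; they do not show what in the cores sets the size, nor whether the same direction would hold on a third core.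

Open, on these data alone, is whether fluoro, nitro or a carboxylic acid in place of hydrogen on the same aromatic carbon would lower the number as bromo does, and whether such steps would also differ in size between the two cores. Also open, as far as these compounds go, is whether a step measured on one further core would lie nearer the smaller or the larger of the two bromo steps.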